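The source may hold more compounds than are shown below. What is called first, only, known or untested is meant among the compounds shown, and "the series" means these compounds.

Measured compounds:
compound 1, `Cc1cc(Cl)cc(-c2ccnc3cc(CN4C(=O)CCC4=O)sc23)c1O[C@H]1C[C@H](N)C1`, 150 nM
compound 2, `Cc1cc(Cl)cc(-c2ccnc3cc(CN4C(=O)C5C(C4=O)C5(C)C)sc23)c1C[C@@H]1CNCCO1`, 25 nM

Of the compounds shown here, two built on a shared core have been measured in an assay on RKO cells for inhibition of ubiquitin carboxyl-terminal hydrolase 7 (Homo sapiens), read by a luciferase reporter, with a stated time of 18 h; on this read-out lower numbers stand for an effect already at smaller amounts and higher numbers for an effect only at larger amounts of compound. Compound 1 (`Cc1cc(Cl)cc(-c2ccnc3cc(CN4C(=O)CCC4=O)sc23)c1O[C@H]1C[C@H](N)C1`) gives 150 nM, the higher of the two numbers. Compound 2 (`Cc1cc(Cl)cc(-c2ccnc3cc(CN4C(=O)C5C(C4=O)C5(C)C)sc23)c1C[C@@H]1CNCCO1`) gives 25 nM in this assay. Compound 2 differs from compound 1 in more than one place. Among the compounds with values here, the two values show only that compound 2 reaches its effect at a smaller amount of compound, and no single change can be credited for the gap.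

Compound 3 (`Cc1cc(Cl)cc(-c2ccnc3cc(CN4C(=O)CCC4=O)sc23)c1CN1CCNC[C@@H]1C`) is not yet measured. It differs from compound 1 in one place: (2-methylpiperazin-1-yl)methyl in place of (3-aminocyclobutyl)oxy on an aromatic carbon. Within the data shown here, no measured pair isolates this change, so the expectation rests on the two measured values alone. The step from compound 1 to compound 3 is expected to be a 1.9-fold lower number from compound 1 to compound 3 (0.27 log units; within the scatter), a modest move toward a lower number rather than none at all. Compound 3 is expected to give about 80 nM in this assay, with a plausible range from 25 nM to 250 nM.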

Compound 3, half-maximal effective concentration: 280 nM
Estimate against measurement, compound 3: 3.5-fold (0.54 log units) below; the measured number lies above the stated range.
By their numbers in this assay, from the lowest: compound 2; then compounds 1 and 3 (each within the scatter of the next).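

At the aromatic carbon ortho to a large group, ortho to a methyl group and para to a chloro group, putting (2-methylpiperazin-1-yl)methyl in place of (3-aminocyclobutyl)oxy gives in this assay a 1.9-fold higher number from compound 1 to compound 3 (0.27 log units; within the scatter). Within the data shown here, this is the first single-place comparison, and it shows that this position can carry a group with a six-membered non-aromatic ring with 2 hetero atoms instead of a four-membered ring of carbon only, with no difference beyond the scatter. Nothing available explains this outcome or says what either group contributes to the read-out.

Compound 2 still differs from both compound 1 and compound 3 in more than one place, so its lower number cannot be assigned to the group on this aromatic carbon or to the other part of the structure. As far as these compounds go, it also remains open how a piperazin-1-ylmethyl group without the methyl, a simple aminomethyl group or a carboxylic acid would read at this position.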